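Lipophilicity notes: five-membered heteroaryl amides on the shared core

A few compounds are considered here, and "the series" means these few. Any claim that something is new, unique, unknown or untested is made for them only; others in the source may bear on it.

Measured compounds:
- Compound 1 `CC(=O)N1CCC(C(=O)N2N=CCC2c2ccccc2)CC1`: in a physicochemical assay for lipophilicity, read by HPLC, measured as chromatographic lipophilicity, at pH 7.4 (on this read-out lower numbers stand for lower lipophilicity and higher numbers for higher lipophilicity), compound 1 gives 2.5.
- Compound 2 `O=C(c1ccccn1)N1CCC(C(=O)N2N=CCC2c2ccccc2)CC1`: in this assay compound 2 gives 3.1.
- Compound 3 `O=C(c1cocn1)N1CCC(C(=O)N2N=CCC2c2ccccc2)CC1`: in this assay compound 3 gives 2.9.

Compound 3 stands second highest of the three numbers in this assay. Its nearest neighbour is compound 2, and the step of a number 0.20 log units lower from compound 2 to compound 3 (within the scatter) is within the scatter, so no order between these two can be claimed. Its furthest neighbour is compound 1, and the step of a number 0.40 log units higher from compound 1 to compound 3 (beyond the scatter) is beyond the scatter, as is a number 0.60 log units higher from compound 1 to compound 2 (beyond the scatter).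

Compound 4 `O=C(c1c[nH]nn1)N1CCC(C(=O)N2N=CCC2c2ccccc2)CC1` is the next member, not yet measured. It differs from compound 3 at the carbonyl carbon: 1H-1,2,3-triazol-4-yl in place of 1,3-oxazol-4-yl on a carbonyl carbon.

Of the measured steps, those at this position all exchange the group on the carbonyl carbon, so they bear on the change. Both aryl groups raised the number modestly against methyl, and the oxazole-to-pyridine exchange moved it within the scatter. None of them introduces a hydrogen-bond donor, so the step to compound 4 rests on indirect comparison only. Among the measured compounds shown here, the entering ring carries a donor that the leaving ring lacks, and no measured pair shows such an exchange. The expectation for the step of a number 0.70 log units lower from compound 3 to compound 4 (beyond the scatter) is a modest move lower, beyond the scatter. Compound 4 is therefore estimated at 2.2 in this assay, with a range from 1.6 to 2.8.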

Compound 4, distribution coefficient: 2
The estimate for compound 4 lay 0.20 log units above the measured number, and the stated range covers the measured number.
By their numbers in this assay, from the lowest: compound 4; then compound 1; then compounds 3 and 2 (each within the scatter of the next).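

At this carbonyl carbon, 1H-1,2,3-triazol-4-yl is the first group shown to give a number below that of methyl in this assay (a number 0.50 log units lower from compound 1 to compound 4 (beyond the scatter)), whereas both earlier aryl groups gave numbers above it. The position therefore does respond to the identity of the aromatic ring: pyridin-2-yl and 1,3-oxazol-4-yl could not be told apart (a number 0.20 log units lower from compound 2 to compound 3 (within the scatter)), but the triazole separates clearly from both (a number 0.90 log units lower from compound 3 to compound 4 (beyond the scatter); a number 1.10 log units lower from compound 2 to compound 4 (beyond the scatter)), the second step being large and the first coming between two five-membered rings of equal heavy-atom count. The entering ring differs from the leaving ring both in its extra ring nitrogen and in its hydrogen-bond donor, and no supporting data are available to assign the shift to either feature.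

The compounds shown do not separate those two features: a 1-methyl-1H-1,2,3-triazol-4-yl group would keep the ring nitrogens while replacing the ring hydrogen, and a 1H-imidazol-4-yl group would keep a ring hydrogen on nitrogen with one ring nitrogen fewer. On these data alone, whether a phenyl group or a carboxylic acid on this carbonyl carbon would fit the same order also remains open.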